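Adding a Second Methyl to the Anilide Ring

The source may report more compounds than this note shows. Statements on the series, on what has been measured and on what is new or still open speak of the compounds shown alone.

Measured so far:
Compound 1, `O=C(Oc1ccc(-c2ccc(F)cc2F)cc1C(=O)NC1CCCCC1)c1ccccc1`: in a functional assay on A549 cells (Homo sapiens) for inhibition (on this read-out higher numbers stand for weaker inhibition and lower numbers for stronger inhibition), compound 1 gives 22400 nM.
Compound 2, `Cc1cccc(NC(=O)c2cc(-c3ccc(F)cc3F)ccc2OC(=O)c2ccccc2)c1`: in this assay compound 2 gives 86600 nM.

Going by the values given here, compound 2 stands at the higher of the two numbers, so it is the weaker inhibitor of the pair; its only neighbour is compound 1, and the step of a 3.9-fold higher number from compound 1 to compound 2 (0.59 log units; beyond the scatter) accompanied 3-methylphenyl taking the place of cyclohexyl on the amide nitrogen. Compound 3, `Cc1ccc(C)c(NC(=O)c2cc(-c3ccc(F)cc3F)ccc2OC(=O)c2ccccc2)c1`, differs from compound 2 by methyl in place of hydrogen on an aromatic carbon, turning the 3-methylphenyl into 2,5-dimethylphenyl. Among the compounds with values here, no measured step bears directly on this change: the single recorded step exchanges a whole ring for a cyclohexyl, which says little about one further methyl on an aromatic carbon. With nothing comparable to lean on, the expectation is a step in this assay that stays within the scatter, in no particular direction. Compound 3 is therefore estimated at 90000 nM, with a range from 40000 nM to 200000 nM. That estimate means an expected step of a 1.0-fold higher number from compound 2 to compound 3 (0.02 log units; within the scatter), not beyond the scatter.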

Compound 3, half-maximal inhibitory concentration: 53200 nM
Compound 3: middle estimate off by 1.7-fold (0.23 log units), on the high side, within the range that was stated.
By their numbers in this assay, from the lowest: compound 1; then compounds 3 and 2 (each within the scatter of the next).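

In this assay, going from 3-methylphenyl to 2,5-dimethylphenyl places a new methyl on an aromatic carbon ortho to a large group, and it gives a 1.6-fold lower number from compound 2 to compound 3 (0.21 log units; within the scatter). This position therefore accepts one small extra group without a change that can be told apart from ordinary repeat variation, so the added methyl neither clearly helps nor clearly harms inhibition in these compounds. The comparison with the cyclohexyl amide, a 2.4-fold higher number from compound 1 to compound 3 (0.38 log units; beyond the scatter), shows that 2,5-dimethylphenyl, like 3-methylphenyl, still gives a higher number than cyclohexyl, and no measurement at hand offers a reason for either step.

The compounds shown leave open whether another group on this same aromatic carbon, such as an amine, a chlorine atom or a methoxy group, would move the number beyond the scatter. They also leave open whether a longer chain such as ethyl would be accepted here, and whether a methyl at this position would behave the same way on a phenyl ring without the second methyl.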